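Cytotoxicity in the acid-chain amide series: dimethoxy variant

This account rests on a few compounds, and the source may have more. Where it says the series, first, only, none or still open, it means among the compounds named here.

Compound 1 `COc1cccc(-c2ccc(C(=O)N(Cc3cccc(OCCCCCC(=O)O)c3)C(C)C)cc2)c1` and compound 2 `CCOc1cccc(-c2ccc(C(=O)N(Cc3cccc(OCCCCCC(=O)O)c3)C(C)C)cc2)c1` share one core and differ only where methyl replaces hydrogen on a saturated chain carbon bound to an oxygen on an aromatic ring. In an ADME assay on HEK293 cells (Homo sapiens) for cytotoxicity, read by CellTiter-Glo and resazurin assay, with a stated time of 72 h (on this read-out higher numbers stand for an effect only at larger amounts of compound and lower numbers for an effect already at smaller amounts), compound 1 gives a limit of > 20900 nM. In this assay compound 2 likewise gives only a limit, > 20800 nM. The step that the two limits leave unreadable from compound 1 to compound 2 therefore cannot be read; the two values sit at the limit of > 20800 nM in this assay, at which 1 of the 2 values shown sits, and (the limit of > 20900 nM in this assay, at which 1 of the 2 values shown sits), and compound 2 stands at a limit, not at a number. Compound 3 `COc1cc(OC)cc(-c2ccc(C(=O)N(Cc3cccc(OCCCCCC(=O)O)c3)C(C)C)cc2)c1` carries 3,5-dimethoxyphenyl in place of 3-ethoxyphenyl on an aromatic carbon. For the measured compounds named here, no measured step bears on this change, and the only step is itself unreadable, so no direction of change in this assay beyond the scatter is expected. Compound 3 is estimated at 25000 nM, with a range from 8000 nM to 70000 nM, the expected step being a step that the limit leaves unreadable from compound 2 to compound 3, most likely again reported only as a limit.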

Compound 3, half-maximal effective concentration: > 26000 nM
Compound 3 was reported as a limit; the forecaster's own chance of this, stated with the estimate: 85%; middle value at least 1.0-fold (0.01 log units) from the limit.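

In this assay compound 3 gives only a limit (> 26000 nM), so its steps from compound 1 and compound 2, which also stand at limits, cannot be read. Open remains where in this assay any of the three compounds would reach a half-maximal effect, and whether 3,5-dimethoxyphenyl and 3-ethoxyphenyl differ there at all.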